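A few compounds are considered here, and "the series" means these few. Any claim that something is new, unique, unknown or untested is made for them only; others in the source may bear on it.

Compound 1 `O=C1COc2ccc(-n3cc(C[C@H](O)COCCOC[C@@H](O)Cc4ccc(-c5ccccc5)cc4)nn3)cc2N1` is the starting point; in a functional assay on SGC-7901 cells (Homo sapiens) for inhibition, read by MTT assay, with a stated time of 72 h (a lower number here means a stronger inhibitor of growth, a higher number a weaker inhibitor of growth), compound 1 gives 15200 nM. Its neighbour compound 2 `O[C@H](COCCOC[C@@H](O)Cc1cn(-c2ccc3c(c2)OCCO3)nn1)Cc1ccc(-c2ccccc2)cc1` keeps the whole chain and differs only in the group on the aromatic nitrogen; in this assay compound 2 gives 6400 nM. The step of a 2.4-fold lower number from compound 1 to compound 2 (0.38 log units; beyond the scatter) is the only measured one, and it leaves compound 2 with the lowest of the two numbers shown, compound 1 standing a modest distance above it.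

Compound 3 `O[C@H](COCCOC[C@@H](O)Cc1cn(-c2cncc3ccccc23)nn1)Cc1ccc(-c2ccccc2)cc1` changes the same position again: isoquinolin-4-yl in place of 2,3-dihydro-1,4-benzodioxin-6-yl on an aromatic nitrogen. Among the measured compounds shown here, the one step that bears on this position, a 2.4-fold lower number from compound 1 to compound 2 (0.38 log units; beyond the scatter), was modest, so a swap of one bicyclic group for another at the same place is expected to move the number by a similar modest amount or less, in no firm direction. Compound 3 is therefore estimated at 5000 nM, within 1500 nM to 20000 nM, a step of a 1.3-fold lower number from compound 2 to compound 3 (0.11 log units; within the scatter) that is expected to stay close to compound 2.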

Compound 3, concentration for 50% growth inhibition: 29300 nM
Compound 3: middle estimate off by 5.9-fold (0.77 log units), on the low side; the whole stated range lies below it.
By their numbers in this assay, from the lowest: compound 2; then compounds 1 and 3 (each within the scatter of the next).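

In this assay this position on the aromatic nitrogen turns out to move the number upward as well as downward: isoquinolin-4-yl in place of 2,3-dihydro-1,4-benzodioxin-6-yl gives a 4.6-fold higher number from compound 2 to compound 3 (0.66 log units; beyond the scatter) even though both groups hold 10 heavy atoms. The step of a 1.9-fold higher number from compound 1 to compound 3 (0.29 log units; within the scatter) lies within the scatter, so among these three only compound 2 stands apart, and its 2,3-dihydro-1,4-benzodioxin-6-yl group is the one group here that separates from the others. No measurement at hand accounts for this difference.

As far as these compounds go, all three compounds carry a bicyclic group at this place, so it stays open how a plain phenyl ring or a phenyl ring bearing a methoxy group would read there. From the compounds shown here alone, it also stays open whether the two ring oxygens or the ring nitrogen matter more, since the two groups differ in both.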